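Replacing 1-methyl-1H-pyrazol-4-yl with 2-oxopyrrolidin-1-yl on the shared core

This account rests on a few compounds, and the source may have more. Where it says the series, first, only, none or still open, it means among the compounds named here.

Two compounds have readings so far in a physicochemical assay for solubility, read by LC-MS, in phosphate buffer, with a stated time of 24 h, at pH 7.4 (a higher number here means a more soluble compound, a lower number a less soluble compound), and their numbers lie apart by more than the scatter. Compound 1 (`Cn1cc(-c2cnc(NCc3c(F)ccc4c3CCO4)c3cn[nH]c(=O)c23)cn1`) gives 1000 nM as the lower of the two numbers. Compound 2 (`O=C1c2ccccc2CN1c1cnc(NCc2c(F)ccc3c2CCO3)n2cnnc12`) gives 4000 nM as the higher one. These two differ in more than one place, so the gap cannot be tied to a single change.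

Next in line is compound 3 (`O=C1CCCN1c1cnc(NCc2c(F)ccc3c2CCO3)c2cn[nH]c(=O)c12`), where 2-oxopyrrolidin-1-yl stands in place of 1-methyl-1H-pyrazol-4-yl on an aromatic carbon of the core of compound 1. The counted difference is 2-oxopyrrolidin-1-yl in place of 1-methyl-1H-pyrazol-4-yl on an aromatic carbon and nothing else changes.

Going by the values given here, no measured pair isolates this replacement, so the expectation rests on thin ground. Among the compounds with values here, the one weak pointer is compound 2 with 4000 nM as its reading, since it also lacks the 1-methyl-1H-pyrazol-4-yl group. In this assay a small upward move is expected, not clearly beyond the scatter, and the estimated size is a 2.0-fold higher number from compound 1 to compound 3 (0.30 log units; within the scatter) for now. Compound 3 is estimated at 2000 nM with an expected range from 700 nM to 6000 nM in this measurement.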

Compound 3, solubility: < 2000 nM
Compound 3 gave a limit, no number (the forecaster's own chance of this, stated with the estimate: 5%); the middle value lies on the limit itself.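

In this assay compound 3 gives < 2000 nM, which is a limit and not a number. Going by these compounds alone, no step from compound 1 to compound 3 can be read from this, so 2-oxopyrrolidin-1-yl in place of 1-methyl-1H-pyrazol-4-yl has no readable size. The compounds shown leave open where compound 3 stands relative to compound 1 in this assay.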